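A few compounds are considered here, and "the series" means these few. Any claim that something is new, unique, unknown or untested is made for them only; others in the source may bear on it.

Measured so far:
- compound 1 `O=C(CN1CCCC1)Nc1nc(-c2ccccc2)cs1`: 49.2%
- compound 2 `COc1ccc(-c2csc(NC(=O)CN3CCCCC3)n2)cc1`: 53.3%

In a functional assay on the whole organism (strain AKR) for inhibition, with Rattus norvegicus as the target, read by paw edema, at a dose of 0.2 mmol/kg by the intraperitoneal route, in the presence of a further agent that is not named here (on this read-out higher numbers stand for more inhibition at the one dose given (going by the name of the read-out) and lower numbers for less inhibition), compound 2 stands at the upper end of the two numbers shown, but its gap to compound 1 lies within the scatter, so the two values show no separation. Within the data shown here, compound 1 and compound 2 differ from each other in two places at once, so no single-change step is available from the measured pair.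

Compound 3 `COc1ccc(-c2csc(NC(=O)CN3CCCC3)n2)cc1` is not yet measured. It differs from compound 2 by pyrrolidin-1-yl in place of piperidin-1-yl on a saturated chain carbon bound to a carbonyl carbon. Nothing measured here isolates this change, so the expectation rests on the two values alone, which sit close together. The step from compound 2 to compound 3 is expected to be a number 3.3 percentage points lower from compound 2 to compound 3 (within the scatter), no change beyond the scatter in either direction. For compound 3 the estimate is 50%, with a range from 35% to 65%.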

Compound 3, a percentage reported as inhibition, in the whole organism at one dose (the size of the read-out at that dose, not a potency): 55%
For compound 3 the middle estimate is 5 percentage points below the measured one; low and high end bracket the measured number.
By their numbers in this assay, from the lowest: compounds 1, 2 and 3 (each within the scatter of the next).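

In this assay, among these compounds, pyrrolidin-1-yl in place of piperidin-1-yl on a saturated chain carbon bound to a carbonyl carbon gives a number 1.7 percentage points higher from compound 2 to compound 3 (within the scatter) and so, read alone for the first time, this ring change shows no separation on the methoxy-bearing core. Methoxy in place of hydrogen on an aromatic carbon, with pyrrolidin-1-yl held constant, gives a number 5.8 percentage points higher from compound 1 to compound 3 (within the scatter) and so this change, also read alone for the first time, shows no separation either. No measurement here bears on what lies behind these two steps.

The compounds shown leave open whether a morpholin-4-yl or diethylamino group at this position, or a longer chain between the carbonyl and the amine, would move the number beyond the scatter. Going by these compounds, a chlorine or a hydroxyl in place of methoxy also remains open.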